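Changing the amide group on a weakly active pair

This account rests on a few compounds, and the source may have more. Where it says the series, first, only, none or still open, it means among the compounds named here.

In a functional assay on MCF7 cells (Homo sapiens) for antiproliferative activity, read by MTT assay, with a stated time of 24 h (on this read-out higher numbers stand for weaker inhibition and lower numbers for stronger inhibition), compound 1 `CCCCc1oc2ccccc2c1C(=O)c1ccc(OCC(=O)N2CCCC2)cc1` gives 42400 nM and compound 2 `CCCCc1oc2ccccc2c1C(=O)c1ccc(OCC(=O)Nc2ccccc2)cc1` gives 33600 nM. Among the measured compounds shown here, the one measured step, a 1.3-fold lower number from compound 1 to compound 2 (0.10 log units; within the scatter), anilino in place of pyrrolidin-1-yl on a carbonyl carbon, lies within the scatter, so these two values cannot be told apart. Compound 3 `CCCCc1oc2ccccc2c1C(=O)c1ccc(OCC(=O)N[C@@H](C)c2ccccc2)cc1` differs from compound 2 by 1-phenylethyl in place of phenyl on an amide-type nitrogen. For the measured compounds named here, with that single step as the only guide, the expected result is a 1.1-fold lower number from compound 2 to compound 3 (0.05 log units; within the scatter), nothing beyond the scatter. Compound 3 is estimated at 30000 nM, within a range of 12000 nM to 60000 nM.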

Compound 3, half-maximal inhibitory concentration: 17900 nM
Compound 3: the middle estimate sits 1.7-fold (0.22 log units) above what was measured; low and high end bracket the measured number.
By their numbers in this assay, from the lowest: compounds 3, 2 and 1 (each within the scatter of the next, the first and the last beyond it).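

Among the compounds shown here, the step of a 2.4-fold lower number from compound 1 to compound 3 (0.37 log units; beyond the scatter) in this assay is the first to lie beyond the scatter, though only modestly, so (1-phenylethyl)amino can be told apart from pyrrolidin-1-yl on this carbonyl carbon, as anilino could not. The step of a 1.9-fold lower number from compound 2 to compound 3 (0.27 log units; within the scatter) stays within the scatter, so 1-phenylethyl and phenyl on the amide-type nitrogen cannot be separated. No evidence is available to explain these results.

From the compounds shown here alone, whether the mirror-image 1-phenylethyl group would give a similar number remains open. So does the effect of a benzyl group on this nitrogen.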